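Propargyl in Place of the Ester on Sulfur

The source may report more compounds than this note shows. Statements on the series, on what has been measured and on what is new or still open speak of the compounds shown alone.

Measured compounds in an assay on isolated protein for inhibition of protoporphyrinogen oxidase (Homo sapiens), read by capillary electrophoresis; a higher number here means a weaker inhibitor, a lower number a stronger inhibitor:
compound 1, `CCOC(=O)Sc1nc2cc(-n3nc(C(C)(C)C)sc3=O)c(F)cc2s1`: 40 nM
compound 2, `CCOC(=O)CSc1nc2cc(-n3nc(C(C)(C)C)sc3=O)c(F)cc2s1`: 340 nM
compound 3, `CCOC(=O)CCSc1nc2cc(-n3nc(C(C)(C)C)sc3=O)c(F)cc2s1`: 9260 nM

Compound 1 gives the lowest number of the three in this assay. Compound 4, `C#CCSc1nc2cc(-n3nc(C(C)(C)C)sc3=O)c(F)cc2s1`, differs from it in one place: propargyl in place of ethoxycarbonyl on a sulfur. Among the measured compounds shown here, two measured steps bear on this change, both starting from compound 1: an 8.5-fold higher number from compound 1 to compound 2 (0.93 log units; beyond the scatter) and a 230-fold higher number from compound 1 to compound 3 (2.36 log units; beyond the scatter). Each moved the ethoxycarbonyl away from the sulfur and each weakened inhibition, the longer the chain the more so. For the measured compounds named here, compound 4 instead drops the ester altogether and puts propargyl on the same sulfur; no measured pair shows that loss. An expected step of a 7.5-fold higher number from compound 1 to compound 4 (0.88 log units; beyond the scatter) seems plausible, toward weaker inhibition. For compound 4 the estimate is 300 nM, within 60 nM to 1500 nM.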

Compound 4, inhibition constant: 9730 nM
For compound 4 the middle estimate is 32-fold (1.51 log units) below the measured one; the whole stated range lies below it.
By their numbers in this assay, from the lowest: compound 1; then compound 2; then compounds 3 and 4 (each within the scatter of the next).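

In this assay propargyl on this sulfur proves a poor replacement for ethoxycarbonyl, giving a 240-fold higher number from compound 1 to compound 4 (2.39 log units; beyond the scatter) and, against the shorter ester chain, a 29-fold higher number from compound 2 to compound 4 (1.46 log units; beyond the scatter). With a 1.1-fold higher number from compound 3 to compound 4 (0.02 log units; within the scatter), dropping the ester altogether lands level with the longest ester chain shown, so removing it costs no more here than moving it two carbons from the sulfur. Nothing available explains this result. Still open, as far as these compounds go, is whether an amide or a carboxylic acid in place of the ethyl ester, with the carbonyl kept on the sulfur, would hold the low number of compound 1. Also open, from the compounds shown here alone, is whether a propyl chain would match propargyl.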